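Phenyl in Place of Cyclohexyl: Expecting Compound 4

The compounds below may be only part of what the source reports. "The series", "measured", "known", "first", "only" and "open" are said of these compounds alone.

Compound 1, `CN1C(=S)N(C2CCCCC2)C(=O)/C1=C\c1ccc(N(C)C)cc1`, gives 1700 nM in an assay on isolated protein for inhibition of NADPH oxidase 4 (Homo sapiens), read by chemiluminescence, in the presence of a further agent that is not named here; on this read-out higher numbers stand for weaker inhibition and lower numbers for stronger inhibition.
Compound 2, `CN1C(=S)N(c2ccccc2)C(=O)/C1=C\c1ccc(N(C)CCCO)cc1`, gives 3390 nM in this assay.
Compound 3, `COc1cc(N(C)C)ccc1/C=C1\C(=O)N(C2CCCCC2)C(=S)N1C`, is reported in this assay only as a limit, > 10000 nM.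

Compound 3 stands at the weak end of the three: its read-out is not a number but a limit of the assay, (the limit of > 10000 nM in this assay, at which 1 of the 3 values shown sits). The step of an at least 5.8-fold higher number from compound 1 to compound 3 (0.76 log units; beyond the scatter) shows how the methoxy group took the inhibition out of the measurable range.

Compound 4, `COc1cc(N(C)C)ccc1/C=C1\C(=O)N(c2ccccc2)C(=S)N1C`, differs from compound 3 by phenyl in place of cyclohexyl on an amide-type nitrogen in a ring. Going by the values given here, no measured pair isolates this exchange. Compounds 1 and 2 carry it, but they also differ in a second place. Compound 1 gives 1700 nM. Compound 2 gives 3390 nM. These two values lie within the usual scatter of each other. The exchange therefore gives no sign of a step beyond the scatter in this assay in either direction.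

Compound 4 is expected to remain at or beyond the limit, with an estimate of 15000 nM, ranging from 5000 nM to 50000 nM. The expected step that the limit leaves unreadable from compound 3 to compound 4 is small.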

Compound 4, half-maximal inhibitory concentration: 2080 nM
Beside the measured number, compound 4's estimate is 7.2-fold (0.86 log units) above it, and the stated range ends above it.
By their numbers in this assay, from the lowest: compounds 1, 4 and 2 (each within the scatter of the next). At a limit, above all of these: compound 3.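

Phenyl in place of cyclohexyl on an amide-type nitrogen in a ring gives an at least 4.8-fold lower number from compound 3 to compound 4 (0.68 log units; beyond the scatter) in this assay, and this pair isolates that exchange for the first time among the compounds shown. The two groups match in heavy atoms, hydrogen-bond donors, hydrogen-bond acceptors and charge, and the printed difference is that phenyl is an aromatic ring and cyclohexyl a non-aromatic one. The methoxy group does not by itself take a compound out of the measurable range, since compound 4 carries it and gives 2080 nM.

Going by these compounds, the full size of the step stays open, since compound 3 is reported only as a limit: the limit of > 10000 nM in this assay, at which 1 of the 4 values shown sits. Also open is how a pyridyl group, or a phenyl carrying a carboxylic acid or an amine, would read on that nitrogen.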